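Amino for chloro on a weakly active growth inhibitor

A few compounds are considered here, and "the series" means these few. Any claim that something is new, unique, unknown or untested is made for them only; others in the source may bear on it.

Compound 1, `Nc1nn(C(=O)Nc2ccc(Cc3ccccc3)cc2)c2ccccc12`, is the parent of this small set. In a functional assay on IGROV-1 cells (Homo sapiens) for antiproliferative activity, read by sulforhodamine B assay, with a stated time of 48 h (a higher number here means a weaker inhibitor of growth, a lower number a stronger inhibitor of growth), compound 1 gives 48800 nM. Compound 2, `Nc1nn(C(=O)Nc2ccc(Cc3ccccc3)cc2)c2ccc(Cl)cc12`, carries a chloro on the fused carbocyclic ring. In this assay compound 2 gives only a limit, > 100000 nM, not a number. Among the compounds with values here, the one measured step, an at least 2.0-fold higher number from compound 1 to compound 2 (0.31 log units; beyond the scatter), therefore runs from a number to the limit of > 100000 nM in this assay, at which 1 of the 2 values shown sits, so compound 2 stands at the weak edge of what this assay reports.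

Compound 3, `Nc1ccc2c(c1)c(N)nn2C(=O)Nc1ccc(Cc2ccccc2)cc1`, arises from compound 2 by amino in place of chloro on an aromatic carbon. Within the data shown here, no measured step involves an amino at that position, so the only guide is that compound 1, which lacks any substituent there, sits at a finite number while compound 2 does not. Compound 3 is expected near 70000 nM, plausibly between 20000 nM and 200000 nM. That would be an estimated step of an at least 1.4-fold lower number from compound 2 to compound 3 (0.15 log units; that floor lies within the scatter).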

Compound 3, concentration for total growth inhibition: 54100 nM
Estimate against measurement, compound 3: 1.3-fold (0.11 log units) above, within the range that was stated.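

In this assay, the step of a 1.1-fold higher number from compound 1 to compound 3 (0.04 log units; within the scatter) shows that amino and hydrogen on this aromatic carbon cannot be told apart, so an added substituent at this place need not push the reading to the weak edge. Amino also gives a finite reading where chloro does not, with an at least 1.8-fold lower number from compound 2 to compound 3 (0.26 log units; that floor lies within the scatter) as the step between the two groups. That step is only a floor and its true size cannot be read, because compound 2 stands at a limit and not at a number: the limit of > 100000 nM in this assay, at which 1 of the 3 values shown sits.

The compounds shown leave open whether any group on this carbon, such as a methoxy group or a carboxylic acid, would move the reading beyond the scatter towards stronger growth inhibition. They also leave open whether a methyl group would follow chloro or amino here.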